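The compounds below may be only part of what the source reports. "The series", "measured", "known", "first", "only" and "open" are said of these compounds alone.

Compound 1 `COc1ccc(CS(=O)(=O)/C=C/c2ccc(F)cc2)cc1`: 2000 nM in a functional assay on DLD-1 cells (Homo sapiens) for antiproliferative activity, read by trypan blue exclusion; a lower number here means a stronger inhibitor, a higher number a weaker inhibitor
Compound 2 `COc1ccc(CS(=O)(=O)/C=C/c2ccc(F)cc2Cl)cc1`: 4000 nM in this assay

In this assay compound 2 gives the highest of the two numbers; compound 1 is nearest with 2000 nM. The step of a 2.0-fold higher number from compound 1 to compound 2 (0.30 log units; within the scatter) stays within the scatter. Compound 3 `COc1ccc(CS(=O)(=O)/C=C/c2ccc(F)cc2OC)cc1` carries methoxy in place of chloro on an aromatic carbon, ortho to a large group and meta to a fluoro group. Among the measured compounds shown here, only one measured step touches this carbon, a 2.0-fold higher number from compound 1 to compound 2 (0.30 log units; within the scatter), and it did not leave the scatter; no measured step exchanges chloro for methoxy. Compound 3 is therefore expected to move little, a 1.3-fold lower number from compound 2 to compound 3 (0.12 log units; within the scatter). Compound 3 is estimated at 3000 nM, between 1200 nM and 8000 nM.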

Compound 3, half-maximal inhibitory concentration: 15000 nM
The estimate for compound 3 lay 5.0-fold (0.70 log units) below the measured number; the measured number lies above the stated range.
By their numbers in this assay, from the lowest: compounds 1 and 2 (each within the scatter of the next); then compound 3.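

This carbon does not tolerate every change in this assay: methoxy in place of chloro gives a 3.8-fold higher number from compound 2 to compound 3 (0.57 log units; beyond the scatter) and methoxy in place of hydrogen gives a 7.5-fold higher number from compound 1 to compound 3 (0.88 log units; beyond the scatter) while the chloro step stayed within the scatter. Among these compounds, then, methoxy alone sets its compound apart at this carbon. Nothing at hand accounts for this difference. Open, on these data alone, is whether a hydroxy group, an amine or a longer ether chain on this carbon would track methoxy or stay with hydrogen and chloro. As far as these compounds go, whether methoxy acts the same way on other carbons of this ring also remains open.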